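Trading a methoxy for a hydroxy on the aromatic ring

The source may hold more compounds than are shown below. What is called first, only, known or untested is meant among the compounds shown, and "the series" means these compounds.

Of the compounds shown here, three built on one shared core have been measured in a functional assay on cells for inhibition, with Murine T-cell line (Mus musculus) as the target; on this read-out higher numbers stand for weaker inhibition and lower numbers for stronger inhibition. Compound 1 `CC[C@@H]1/C=C(\C)C[C@H](C)C[C@H](OC)[C@H]2O[C@@](O)(C(=O)C(=O)N3CCCC[C@H]3C(=O)O[C@H](/C(C)=C/[C@@H]3CC[C@@H](Oc4ccc(O)cc4)[C@H](OC)C3)[C@H](C)[C@@H](O)CC1=O)[C@H](C)C[C@@H]2OC` gives 0.8 nM. Compound 2 `CC[C@@H]1/C=C(\C)C[C@H](C)C[C@H](OC)[C@H]2O[C@@](O)(C(=O)C(=O)N3CCCC[C@H]3C(=O)O[C@H](/C(C)=C/[C@@H]3CC[C@@H](Oc4ccccc4)[C@H](O)C3)[C@H](C)[C@@H](O)CC1=O)[C@H](C)C[C@@H]2OC` gives 5.2 nM. Compound 3 `CC[C@@H]1/C=C(\C)C[C@H](C)C[C@H](OC)[C@H]2O[C@@](O)(C(=O)C(=O)N3CCCC[C@H]3C(=O)O[C@H](/C(C)=C/[C@@H]3CC[C@@H](Oc4ccc(OC)cc4)[C@H](O)C3)[C@H](C)[C@@H](O)CC1=O)[C@H](C)C[C@@H]2OC` gives 1.2 nM, the second highest of the three numbers; its gap to compound 1 lies within the scatter, while its gap to compound 2 lies beyond it. Going by the values given here, the only measured change at a single point, a 4.3-fold lower number from compound 2 to compound 3 (0.64 log units; beyond the scatter), is a modest gain in inhibition.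

Compound 4 `CC[C@@H]1/C=C(\C)C[C@H](C)C[C@H](OC)[C@H]2O[C@@](O)(C(=O)C(=O)N3CCCC[C@H]3C(=O)O[C@H](/C(C)=C/[C@@H]3CC[C@@H](Oc4ccc(O)cc4)[C@H](O)C3)[C@H](C)[C@@H](O)CC1=O)[C@H](C)C[C@@H]2OC` has not yet been measured. It differs from compound 3 in one place: hydrogen in place of methyl on an oxygen on an aromatic ring. Among the compounds with values here, no measured pair shows exactly this change. Compound 1 carries the same hydroxy on its aromatic ring but differs from compound 3 at a second place as well, so it offers only indirect guidance. Since compound 1 gives 0.8 nM and compound 3 gives 1.2 nM, no step beyond the scatter is expected here. The expected change in this assay is a 1.2-fold lower number from compound 3 to compound 4 (0.08 log units; within the scatter). Compound 4 is therefore estimated at about 1 nM, within a range from 0.4 nM to 3 nM.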

Compound 4, half-maximal inhibitory concentration: 1.6 nM
Compound 4: middle estimate off by 1.6-fold (0.20 log units), on the low side, and the stated range covers the measured number.
By their numbers in this assay, from the lowest: compounds 1, 3 and 4 (each within the scatter of the next); then compound 2.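

In this assay, the step from methoxy to hydroxy on the aromatic ring gives a 1.3-fold higher number from compound 3 to compound 4 (0.12 log units; within the scatter), so 4-methoxyphenoxy and 4-hydroxyphenoxy cannot be told apart here. The hydroxy also stands clear of the bare ring, with a 3.3-fold lower number from compound 2 to compound 4 (0.51 log units; beyond the scatter), so the gain seen earlier with methoxy is matched by a hydroxy at the same place. Removing the other methyl, the one on an oxygen on a saturated carbon, gives a 2.0-fold higher number from compound 1 to compound 4 (0.30 log units; within the scatter), so compound 1 and compound 4 cannot be told apart either.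

No measured evidence here gives a reason for these results. The compounds shown leave open whether an amine, a carboxylic acid or a longer chain such as ethoxy at this place on the aromatic ring would keep the same level of inhibition.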